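Extending a Linker Between Two Rings: Cytotoxicity Outlook

The source may report more compounds than this note shows. Statements on the series, on what has been measured and on what is new or still open speak of the compounds shown alone.

Compound 2 `Fc1cccc(F)c1Cc1cnc(Nc2ccc(Oc3ccncc3)cc2)o1` and compound 1 `COCc1ccc(Nc2ncc(Cc3c(F)cccc3F)o2)cc1` share one core and differ in a single place. In an ADME assay on MT2 cells (Homo sapiens) for cytotoxicity, read by MTT assay (on this read-out lower numbers stand for higher toxicity in this test and higher numbers for lower toxicity in this test), compound 1 gives 32000 nM, and compound 2 gives 21000 nM. The step of a 1.5-fold lower number from compound 1 to compound 2 (0.18 log units; within the scatter) came with (pyridin-4-yl)oxy in place of methoxymethyl on an aromatic carbon. The two numbers thus lie within the scatter of each other, and compound 2 stands beside compound 1 rather than apart from it.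

Compound 3 `Fc1cccc(F)c1Cc1cnc(Nc2ccc(CCOc3ccncc3)cc2)o1` has not been measured. Its change from compound 2: 2-((pyridin-4-yl)oxy)ethyl in place of (pyridin-4-yl)oxy on an aromatic carbon. The group that leaves, (pyridin-4-yl)oxy, and the group that enters, 2-((pyridin-4-yl)oxy)ethyl, sit on an aromatic carbon of a six-membered aromatic ring of carbon only, para to a large group.

Within the data shown here, no measured step repeats this change, so the sole guide is the measured pair, whose step stayed within the scatter. The expected step for compound 3 is therefore a 1.1-fold lower number from compound 2 to compound 3 (0.02 log units; within the scatter), nothing beyond the scatter. Compound 3 is estimated at 20000 nM in this assay, with a range from 8000 nM to 50000 nM.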

Compound 3, half-maximal cytotoxic concentration: 11000 nM
Beside the measured number, compound 3's estimate is 1.8-fold (0.26 log units) above it, and the stated range covers the measured number.
By their numbers in this assay, from the lowest: compounds 3, 2 and 1 (each within the scatter of the next, the first and the last beyond it).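

Lengthening the link to 2-((pyridin-4-yl)oxy)ethyl in place of (pyridin-4-yl)oxy on the aromatic carbon does not clearly separate compound 3 from compound 2 in this assay (a 1.9-fold lower number from compound 2 to compound 3 (0.28 log units; within the scatter)), so the added chain length alone makes no firm difference here. Among these compounds, the comparison with compound 1, where ((pyridin-4-yl)oxy)methyl stands in place of methoxy on a saturated chain carbon bound to an aromatic carbon, is the first in this small set to pass the scatter (a 2.9-fold lower number from compound 1 to compound 3 (0.46 log units; beyond the scatter)), though only modestly, and it shows that this position can carry a much larger group while the number moves toward higher toxicity in this test. Nothing available explains either step.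

Going by these compounds, with three compounds, it remains open whether a longer chain would lower the number further or whether the trend stops at compound 3. On these data alone, it is also open how an amine in place of the ether oxygen, or a carboxylic acid on the far ring, would read in this assay.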